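A few compounds are considered here, and "the series" means these few. Any claim that something is new, unique, unknown or untested is made for them only; others in the source may bear on it.

Compound 1 `CCCn1c(NC(=O)c2ccnn2CC)nc2cc(C(N)=O)cc(OC)c21` gives > 100000 nM in an assay for activation of interferon regulatory factor 3 (Homo sapiens), read by a luciferase reporter, with a stated time of 20 h (a lower number here means that less compound is needed, a higher number that more compound is needed for the effect), which is a limit of the assay and not a number.
Compound 2 `CCCn1c(NC(=O)c2cc3ccccc3n2C)nc2cc(C(N)=O)cc(OC)c21` gives > 100000 nM in this assay, again only a limit.

In this assay compound 2 therefore stands at a limit rather than at a measured value. Both values shown sit at that same limit, as the limit of > 100000 nM in this assay, at which 2 of the 2 values shown sit, records, so the step that the two limits leave unreadable from compound 1 to compound 2 is not readable. Compound 3 `CCCn1c(NC(=O)CCc2ccccc2)nc2cc(C(N)=O)cc(OC)c21` carries the change (phenethyl in place of 1-methyl-1H-indol-2-yl on a carbonyl carbon). Among the measured compounds shown here, the only measured step, from compound 1 to compound 2, bears on it as another exchange on the same carbonyl carbon, yet its size cannot be read, both ends being limits. For the measured compounds named here, no measured step thus gives a direction or size for this assay, and compound 3 is expected to remain near the same limit. The estimated step that the limit leaves unreadable from compound 2 to compound 3 is expected to be none beyond the scatter. For compound 3 the estimate in this assay is 150000 nM, within 30000 nM to 1000000 nM, most likely reported again as a limit.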

Compound 3, half-maximal effective concentration: > 100000 nM
Compound 3: only a limit was reported; the forecaster's own chance of this, stated with the estimate: 85%; the middle value is on the limit's open side.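

In this assay compound 3 gives > 100000 nM, again a limit and not a number. The steps from compound 1 and from compound 2 to compound 3 therefore cannot be read: the limit of > 100000 nM in this assay, at which 3 of the 3 values shown sit.

The compounds shown leave open which group on the carbonyl carbon, if any, would give a measurable value in this assay.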